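One more methoxy on compound 3

This account rests on a few compounds, and the source may have more. Where it says the series, first, only, none or still open, it means among the compounds named here.

In a functional assay on HCT-116 cells (Homo sapiens) for cytotoxicity (on this read-out lower numbers stand for an effect already at smaller amounts and higher numbers for an effect only at larger amounts of compound), compound 1 (`CC(=O)SCC(=O)c1ccc(NS(=O)(=O)c2cccc(Cl)c2)cc1`) stands as "not determined" (no result reported) and yields no number. Compound 2 (`CC(=O)SCC(=O)c1ccc(NS(=O)(=O)c2ccc(Cl)cc2)cc1`) gives 30800 nM there. Compound 3 (`COc1cccc(S(=O)(=O)Nc2ccc(C(=O)CSC(C)=O)cc2)c1`) gives 2600 nM and so holds the lower of the two numbers. Compound 4 (`COc1ccc(S(=O)(=O)Nc2ccc(C(=O)CSC(C)=O)cc2)cc1OC`) has not been measured. It differs from compound 3 by methoxy in place of hydrogen on an aromatic carbon. Within the data shown here, only one measured step bears on this, the large 12-fold lower number from compound 2 to compound 3 (1.07 log units; beyond the scatter) (3-methoxyphenyl in place of 4-chlorophenyl on a sulfonyl sulfur), and it does not isolate an added methoxy. No change beyond the scatter is therefore expected, only a slight lean to a higher number. The estimated step of a 1.5-fold higher number from compound 3 to compound 4 (0.19 log units; within the scatter) stays small. For compound 4 the estimate in this assay is 4000 nM with 1200 nM to 15000 nM as the expected range.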

Compound 4, half-maximal effective concentration: 3200 nM
Compound 4: the middle estimate sits 1.3-fold (0.10 log units) above what was measured, and the stated range covers the measured number.
By their numbers in this assay, from the lowest: compounds 3 and 4 (each within the scatter of the next); then compound 2.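

In this assay, methoxy in place of hydrogen on this aromatic carbon, ortho to a methoxy group and para to a large group, gives a 1.2-fold higher number from compound 3 to compound 4 (0.09 log units; within the scatter) and so leaves the read-out within the scatter. Among these compounds, the one earlier step exchanged a whole substituent on the sulfonyl sulfur, so it could not show what an added methoxy does alone. Nothing at hand offers an explanation for this outcome.

Going by these compounds, whether an amine, a hydroxyl group or a longer alkoxy chain on this carbon would behave like methoxy stays open.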